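The source may hold more compounds than are shown below. What is called first, only, known or untested is meant among the compounds shown, and "the series" means these compounds.

Measured in a functional assay on a cell-free system (plasma, Homo sapiens), with a stated time of 3 min; on this read-out lower numbers stand for stronger inhibition and higher numbers for weaker inhibition:
compound 1 `CC(C)(C)C[C@@H](O)C(=O)N1CC[C@@H]2C[C@@]21C(=O)NCc1cc(Cl)ccc1-n1cnnn1` gives 620 nM
compound 2 `O=C(NCc1cc(Cl)ccc1-n1cnnn1)[C@@H]1C[C@@H]2C[C@@H]2N1C(=O)[C@H](O)c1cccc(Cl)c1` gives 1000 nM
compound 3 `O=C(NCc1cc(Cl)ccc1-n1cnnn1)[C@@H]1[C@H]2C[C@H]2CN1C(=O)[C@H](O)Cn1cccn1` gives 1800 nM

Of these three numbers, compound 2 has the second highest. The nearest is compound 1, whose number is lower, yet the gap lies within the usual scatter of repeated measurements; compound 3 has a higher number, and that gap too lies within the scatter. So the three compounds cannot be ranked against each other.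

Compound 4 `O=C(NCc1cc(Cl)ccc1-n1cnnn1)[C@@H]1C[C@@H]2C[C@@H]2N1C(=O)[C@H](O)C1CCCCC1` differs from compound 2 in one place: cyclohexyl in place of 3-chlorophenyl on a saturated chain carbon bound to a carbonyl carbon and an oxygen on a saturated carbon. Among the compounds with values here, no measured pair shows this kind of change, so the step from compound 2 to compound 4 is expected to be small, a 1.3-fold lower number from compound 2 to compound 4 (0.12 log units; within the scatter), not beyond the scatter. Compound 4 is estimated at 750 nM, with a range from 250 nM to 2200 nM.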

Compound 4, half-maximal inhibitory concentration: 600 nM
Beside the measured number, compound 4's estimate is 1.3-fold (0.10 log units) above it; measured number inside the range.
By their numbers in this assay, from the lowest: compounds 4, 1, 2 and 3 (each within the scatter of the next, the first and the last beyond it).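

Within the data shown here, this is the first pair of compounds that differ in one place, and cyclohexyl in place of 3-chlorophenyl gives a 1.7-fold lower number from compound 2 to compound 4 (0.22 log units; within the scatter) in this assay. So at this position, compound 2 and compound 4 cannot be told apart, and in this one pair neither the aromatic ring nor its chlorine is needed to keep inhibition at this level. Nothing available explains why the two groups read alike. One pair cannot show how far this holds at this position. An amine or a carboxylic acid in place of the ring might read quite differently.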